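Swapping an Acid for an Amide on a Shared Core

A few compounds are considered here, and "the series" means these few. Any claim that something is new, unique, unknown or untested is made for them only; others in the source may bear on it.

Measured so far:
- compound 1, `Cc1nc(-c2ccc(C(F)(F)F)cc2)sc1CNc1ccc(CCC(=O)O)cc1`, 108%
- compound 2, `Cc1nc(-c2ccc(C(F)(F)F)cc2)sc1CNc1ccc(OCC(=O)O)cc1`, 100%
- compound 3, `Cc1nc(-c2ccc(C(F)(F)F)cc2)sc1CNc1ccc(C(C)CC(=O)O)cc1`, 109%

All three compounds share one core and carry a carboxylic acid on a chain attached to the outer aromatic ring. In a functional assay on CHO cells for agonist activity at Free fatty acid receptor 1 (Homo sapiens), read by a luciferase reporter (on this read-out lower numbers stand for smaller maximal responses and higher numbers for larger maximal responses), compound 3 stands highest of the three numbers, but its nearest neighbour is compound 1, a number 1 percentage points higher from compound 1 to compound 3 (within the scatter), and its furthest is compound 2, a number 9 percentage points higher from compound 2 to compound 3 (within the scatter). Compound 3 is therefore not separable from the others on this read-out.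

Compound 4, `Cc1nc(-c2ccc(C(F)(F)F)cc2)sc1CNc1ccc(CCC(N)=O)cc1`, is not yet measured. It differs from compound 3 in one place: 2-carbamoylethyl in place of 1-(carboxymethyl)ethyl on an aromatic carbon. The acid is gone and a primary amide stands in its stead.

Among the compounds with values here, none of the measured steps covers such a change. The steps of a number 8 percentage points lower from compound 1 to compound 2 (within the scatter) and a number 1 percentage points higher from compound 1 to compound 3 (within the scatter) alter the chain that carries the acid while keeping the acid itself, and both lie within the scatter. From the compounds shown here alone, what the data show is that the maximal response has not moved with the chain; whether it survives the loss of the acid is untested. The estimate for compound 4 in this assay is expected to lie around 85%, between 40% and 115%, so the expected step of a number 24 percentage points lower from compound 3 to compound 4 (beyond the scatter) carries wide uncertainty.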

Compound 4, largest response reached (reported as percent of maximum), in percent of the reference or control that the assay uses: 88%
The estimate for compound 4 lay 3 percentage points below the measured number, within the range that was stated.
By their numbers in this assay, from the lowest: compound 4; then compounds 2, 1 and 3 (each within the scatter of the next).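

Within this assay the exchange of hydroxy for amino on the carbonyl carbon, with the chain left as it is, gives a number 20 percentage points lower from compound 1 to compound 4 (beyond the scatter) and so lowers the maximal response without abolishing it, which shows that a carboxylic acid is not required for a clear response on the shared core. Within the data shown here, the steps of a number 21 percentage points lower from compound 3 to compound 4 (beyond the scatter) and a number 12 percentage points lower from compound 2 to compound 4 (beyond the scatter) run the same way, although each also alters the chain; the earlier changes to the chain alone stayed within the scatter, so replacing the acid with a primary amide is the first change at this position that moves the number beyond it. No measurement shown here says what lies behind this drop.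

The compounds shown leave open how other replacements for the acid would behave on the same chain, such as a methyl ester, a tetrazole or an amide bearing a methyl group on its nitrogen. They also leave open whether the primary amide would give a similar response on a longer chain or on the carboxymethoxy chain.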